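Removing the aromatic amino group from compound 2

This account rests on a few compounds, and the source may have more. Where it says the series, first, only, none or still open, it means among the compounds named here.

In a physicochemical assay for solubility, at pH 7.4 (on this read-out higher numbers stand for higher solubility and lower numbers for lower solubility), compound 2 `C[C@H]1[C@H](N)CN1c1c(F)c(N)c2c(=O)c(C(=O)O)cn(C3CC3)c2c1F` gives 37.7 ug/mL, the highest of the two single numbers in this set. The nearest single number belongs to compound 1 `CNC1(C)CN(c2c(F)cc3c(=O)c(C(=O)O)cn(C4CC4)c3c2F)C1`, which in this assay gives 0.5 ug/mL, a gap that lies beyond the usual scatter. Compound 3 `CC1(N)CN(c2c(F)cc3c(=O)c(C(=O)O)cn(C4CC4)c3c2F)C1` has been measured more than once in this assay and gives 0.8 ug/mL; 15.3 ug/mL (2 entries); the spread between these entries, (the several entries of compound 3 in this assay, 0.8 ug/mL; 15.3 ug/mL (2 entries)), is itself a caution on how far any single number here can be trusted.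

Compound 4 `C[C@H]1[C@H](N)CN1c1c(F)cc2c(=O)c(C(=O)O)cn(C3CC3)c2c1F` has not yet been measured in this assay. It differs from compound 2 by hydrogen in place of amino on an aromatic carbon. Compounds 1 and 3, like compound 4, carry no amino group on that ring. Compound 1 sits at 0.5 ug/mL and compound 3 at 0.8 ug/mL; 15.3 ug/mL (2 entries), and on that basis a downward step from compound 2 is expected, larger than the scatter. The expected step is a 9.4-fold lower number from compound 2 to compound 4 (0.97 log units; beyond the scatter). For compound 4 the estimated solubility is 4 ug/mL, with a range from 0.6 ug/mL to 25 ug/mL.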

Compound 4, solubility: 23.2 ug/mL
Estimate against measurement, compound 4: 5.8-fold (0.76 log units) below, and the stated range covers the measured number.
By their numbers in this assay, from the lowest: compound 1; then compounds 4 and 2 (each within the scatter of the next).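

In this assay, hydrogen in place of amino on this aromatic carbon, ortho to a fluoro group, leaves the read-out within the scatter: a 1.6-fold lower number from compound 2 to compound 4 (0.21 log units; within the scatter). The wide gap between compound 2 and compound 1 therefore does not follow the amino group alone, and the large step appears instead where a group of 6 heavy atoms replaces a group of 7 on an aromatic carbon: a 46-fold higher number from compound 1 to compound 4 (1.67 log units; beyond the scatter). Steps to compound 3 cannot be read, as its entries disagree too widely to place it: the several entries of compound 3 in this assay, 0.8 ug/mL; 15.3 ug/mL (2 entries)

The compounds shown do not tell how a methoxy or hydroxyl group on this aromatic carbon would read. As far as these compounds go, they also do not separate which part of the group on the four-membered ring goes with the large step, and a longer chain on its amine remains open too.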